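Swapping the cyanofluorophenyl of compound 1 for a fluorophenyl

This account rests on a few compounds, and the source may have more. Where it says the series, first, only, none or still open, it means among the compounds named here.

Measured compounds:
- compound 1, `N#Cc1cc(-c2nc(C(c3ccc(F)cc3)c3ccc(F)cc3)sc2CC(=O)O)ccc1F`: 520 nM
- compound 2, `CCC(c1ccccc1)c1nc(-c2ccc(Cl)cc2)c(CC(=O)O)s1`: > 100000 nM
- compound 3, `O=C(O)Cc1sc(C(c2ccccc2)c2ccccc2)nc1-c1ccc(F)c(F)c1`: 43 nM

Three compounds sharing a common core, each carrying a carboxymethyl group, have been tested in an in vitro functional assay on HEK285-7 cells for antagonist activity at prostaglandin D2 receptor 2 (Homo sapiens), read by BRET and beta-arrestin recruitment; a lower number here means a stronger inhibitor, a higher number a weaker inhibitor. Compound 1 gives 520 nM, the highest of the two numbers that were actually read. Compound 3 gives 43 nM, a lower number and beyond the usual scatter of the measurement. Compound 2 reaches only a limit of this assay, > 100000 nM, and no number for it is known; (the limit of > 100000 nM in this assay, at which 1 of the 3 values shown sits).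

Compound 4, `O=C(O)Cc1sc(C(c2ccc(F)cc2)c2ccc(F)cc2)nc1-c1cccc(F)c1`, has not yet been measured. It differs from compound 1 in one place, (3-fluorophenyl in place of 3-cyano-4-fluorophenyl on an aromatic carbon), on the aromatic carbon that is next to the ring nitrogen and next to the ring atom that bears the carboxymethyl group. Because compound 3, which also carries a fluorinated phenyl here, gives 43 nM, a moderate step toward a lower number is expected, yet smaller than the gap between compound 1 and compound 3. Compound 4 is therefore estimated at 150 nM, with a range from 40 nM to 600 nM, an expected step of a 3.5-fold lower number from compound 1 to compound 4 (0.54 log units; beyond the scatter).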

Compound 4, half-maximal inhibitory concentration: 18 nM
For compound 4 the middle estimate is 8.3-fold (0.92 log units) above the measured one; measured number below the stated range.
By their numbers in this assay, from the lowest: compound 4; then compound 3; then compound 1. At a limit, above all of these: compound 2.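

Among these compounds, this is the first step between two measured compounds that differ in one place, so the effect of this position can now be read with the rest of the molecule held constant. Replacing 3-cyano-4-fluorophenyl with 3-fluorophenyl on the aromatic carbon next to the ring nitrogen gives a 29-fold lower number from compound 1 to compound 4 (1.46 log units; beyond the scatter), so the number is highly sensitive to the group at this position. The change alters two things at once, since the nitrile leaves and the fluorine stands in a different place on the phenyl ring, and nothing shown explains the size of the step.

The compounds shown cannot separate the loss of the nitrile from the shift of the fluorine. From the compounds shown here alone, how a methoxy group or an amine on this phenyl ring would affect the number also remains open.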